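The source may report more compounds than this note shows. Statements on the series, on what has been measured and on what is new or still open speak of the compounds shown alone.

Measured in a functional assay on SK-MEL-28 cells (Homo sapiens) for cytotoxicity, read by MTT assay, with a stated time of 3 days; a higher number here means a weaker inhibitor, a lower number a stronger inhibitor:
- compound 1 `CNc1nc(SCc2nc3ccccc3[nH]2)nc(-c2ccccc2)c1C#N`: 2.87 nM
- compound 2 `N#Cc1c(Nc2ccccn2)nc(SCc2nc3ccccc3[nH]2)nc1-c1ccccc1`: 8.9 nM

Of these two, compound 2 has the higher number, 8.9 nM, which makes it the weaker inhibitor. Compound 3 `N#Cc1c(NC(N)=S)nc(SCc2nc3ccccc3[nH]2)nc1-c1ccccc1` keeps the shared core and changes one group: a group of 3 heavy atoms (1 carbon, 1 nitrogen, 1 sulfur; no ring) in place of a group of 6 heavy atoms (5 carbon, 1 nitrogen; one six-membered aromatic ring with 1 hetero atom), on a nitrogen on an aromatic ring. Going by the values given here, one measured step bears on this, a change on the same nitrogen: a 3.1-fold higher number from compound 1 to compound 2 (0.49 log units; beyond the scatter). Among the compounds with values here, that modest step from compound 1 is the only guide, and no measured compound carries the entering group, so no step beyond the scatter is expected in this assay, in either direction. The expected change is a 1.5-fold lower number from compound 2 to compound 3 (0.17 log units; within the scatter). The estimated value for compound 3 is 6 nM, with an expected range of 1.5 nM to 25 nM.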

Compound 3, half-maximal inhibitory concentration: 4.8 nM
Compound 3: middle estimate off by 1.3-fold (0.10 log units), on the high side; the range from low to high includes it.
By their numbers in this assay, from the lowest: compounds 1, 3 and 2 (each within the scatter of the next, the first and the last beyond it).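

In this assay, a group with no ring on this nitrogen gives a 1.9-fold lower number from compound 2 to compound 3 (0.27 log units; within the scatter), and set against the small methyl it gives a 1.7-fold higher number from compound 1 to compound 3 (0.22 log units; within the scatter). So compound 3 cannot be told apart from either compound, even though compound 1 and compound 2 do differ from each other beyond the scatter. Nothing available explains why this nitrogen tolerates such different groups. On these data alone, whether a longer chain such as butyl, or a phenyl ring, on the same nitrogen would fit this picture remains open.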